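Replacing the aryl group on the shared core of compound 1

This account rests on a few compounds, and the source may have more. Where it says the series, first, only, none or still open, it means among the compounds named here.

Among the compounds with values here, compound 1 `O=[N+]([O-])c1ccc(CN2CCC(n3cc(CC(OCc4cc(-c5ccc(Br)cc5)no4)c4ccc(Br)cc4)nn3)CC2)cc1` is one of three compounds tested in a functional assay on MDA-MB-468 cells (Homo sapiens) for cytotoxicity, with a stated time of 48 h (on this read-out lower numbers stand for stronger inhibition and higher numbers for weaker inhibition), and compound 1 gives 5000 nM, the only plain number among the three. Compound 2 `COc1cccc(-c2cc(COC(Cc3cn(C4CCN(Cc5ccc([N+](=O)[O-])cc5)CC4)nn3)c3ccc(Br)cc3)on2)c1` is reported as a limit of the assay, at > 25000 nM. Compound 3 `O=[N+]([O-])c1ccc(CN2CCC(n3cc(CC(OCc4cc(-c5ccccc5Br)no4)c4ccc(Br)cc4)nn3)CC2)cc1` is likewise reported only as a limit, at > 25000 nM. Both changes away from compound 1 therefore read as an at least 5.0-fold higher number from compound 1 to compound 2 (0.69 log units; beyond the scatter) and an at least 5.0-fold higher number from compound 1 to compound 3 (0.69 log units; beyond the scatter), each resting on (the limit of > 25000 nM in this assay, at which 2 of the 3 values shown sit).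

Compound 4 `O=[N+]([O-])c1ccc(CN2CCC(n3cc(CC(OCc4cc(-c5ccccc5F)no4)c4ccc(Br)cc4)nn3)CC2)cc1` has not been measured. It differs from compound 1 by 2-fluorophenyl in place of 4-bromophenyl on an aromatic carbon. Within the data shown here, the closest measured step is the one from compound 1 to compound 3, where a 2-bromophenyl took the same position and the number rose at least modestly; the step to compound 2 points the same way. A weaker outcome than compound 1 is thus expected, quite possibly again at the limit, and compound 4 is estimated at 20000 nM (range 6000 nM to 60000 nM), which means an expected step of a 4.0-fold higher number from compound 1 to compound 4 (0.60 log units; beyond the scatter).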

Compound 4, half-maximal inhibitory concentration: 4000 nM
Compound 4: the middle estimate sits 5.0-fold (0.70 log units) above what was measured, and the stated range ends above it.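

In this assay, replacing the 4-bromophenyl does not necessarily weaken the compound: the 2-fluorophenyl gives a 1.3-fold lower number from compound 1 to compound 4 (0.10 log units; within the scatter), so this carbon can carry a different aryl group with the number staying within the usual scatter. The identity of the halogen on the aryl group also matters, since exchanging only bromo for fluoro gives an at least 6.2-fold lower number from compound 3 to compound 4 (0.79 log units; beyond the scatter). The change from 3-methoxyphenyl to 2-fluorophenyl gives an at least 6.2-fold lower number from compound 2 to compound 4 (0.79 log units; beyond the scatter), and both of these steps start from a limit of the assay rather than a plain number: the limit of > 25000 nM in this assay, at which 2 of the 4 values shown sit.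

The compounds shown leave open whether a plain phenyl, a 2-chlorophenyl or a 2-aminophenyl on this carbon would behave like compound 4 or like compound 3. A 4-fluorophenyl would also be needed to separate the effect of fluoro itself from the effect of where it sits on the aryl ring.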